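The source may hold more compounds than are shown below. What is called first, only, known or untested is meant among the compounds shown, and "the series" means these compounds.

Three compounds share one core, a sulfonamide joined through a three-carbon chain to an amine, and differ only in the aromatic group on the carbon next to that amine. Compound 1 `O=S(=O)(NCCCNCc1cccc2ccccc12)c1cc(C(F)(F)F)cc(C(F)(F)F)c1` gives, in a functional assay on A2780 cells (Homo sapiens) for inhibition, read by MTT assay, with a stated time of 72 h (on this read-out lower numbers stand for stronger inhibition of growth and higher numbers for weaker inhibition of growth), a value of 3100 nM. Compound 2 `CC(C)(C)c1ccc(CNCCCNS(=O)(=O)c2cc(C(F)(F)F)cc(C(F)(F)F)c2)cc1` gives 2900 nM in this assay, and compound 3 `COc1cccc(CNCCCNS(=O)(=O)c2cc(C(F)(F)F)cc(C(F)(F)F)c2)c1` gives 1600 nM. Compound 3 thus carries the lowest of the three numbers, yet the steps to it, a 1.9-fold lower number from compound 1 to compound 3 (0.29 log units; within the scatter) and a 1.8-fold lower number from compound 2 to compound 3 (0.26 log units; within the scatter), both fall within the scatter, as does a 1.1-fold lower number from compound 1 to compound 2 (0.03 log units; within the scatter). Compound 4 `O=S(=O)(NCCCNCc1cccc(Cl)c1)c1cc(C(F)(F)F)cc(C(F)(F)F)c1` changes the same aromatic group again: chloro in place of methoxy on an aromatic carbon. Since every swap of this group so far stayed within the scatter, the expected step is small, a 1.1-fold higher number from compound 3 to compound 4 (0.05 log units; within the scatter), and compound 4 is estimated at 1800 nM, between 800 nM and 4000 nM.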

Compound 4, concentration for 50% growth inhibition: 2200 nM
Compound 4: the middle estimate sits 1.2-fold (0.09 log units) below what was measured, and the stated range covers the measured number.
By their numbers in this assay, from the lowest: compounds 3, 4, 2 and 1 (each within the scatter of the next).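

Chloro in place of methoxy on an aromatic carbon, meta to a large group, is a change of one small group on the same ring rather than a swap of the whole aromatic group, and it too stays within the scatter (a 1.4-fold higher number from compound 3 to compound 4 (0.14 log units; within the scatter)). The steps from the other two compounds also stay within it (a 1.3-fold lower number from compound 2 to compound 4 (0.12 log units; within the scatter); a 1.4-fold lower number from compound 1 to compound 4 (0.15 log units; within the scatter)), so these four aromatic groups cannot be told apart in this assay. Nothing at hand explains this result.

Going by these compounds, whether a nitrile or a carboxylic acid at this place on the ring would give a step beyond the scatter remains open. So does the effect of a longer chain in place of the three-carbon chain.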